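The source may report more compounds than this note shows. Statements on the series, on what has been measured and on what is new or still open speak of the compounds shown alone.

In a functional assay on HeLa cells (Homo sapiens) for cytotoxicity, read by MTT assay, with a stated time of 48 h (a lower number here means a stronger inhibitor, a higher number a weaker inhibitor), compound 1 `O=C(O)CN1C(=O)/C(=C/c2nc3ccccc3n2Cc2ccc(Br)cc2)SC1=S` gives 12900 nM, and compound 3 `O=C(O)CN1C(=O)/C(=C/c2nc3ccccc3n2Cc2ccc([N+](=O)[O-])cc2)SC1=S` gives 18600 nM, within the scatter of each other. Compound 2 `O=C(O)CN1C(=O)/C(=C/c2nc3ccccc3n2Cc2ccc(Br)cc2F)SC1=S` gives > 50000 nM, which is a limit and not a number. Compound 4 `O=C(O)CN1C(=O)/C(=C/c2nc3ccccc3n2Cc2ccc(F)cc2)SC1=S` carries fluoro in place of bromo on an aromatic carbon, para to a large group: fluoro in place of bromo on an aromatic carbon. For the measured compounds named here, the closest precedent is the replacement of that same bromo in a 1.4-fold higher number from compound 1 to compound 3 (0.16 log units; within the scatter), which lies within the scatter. Less directly, an at least 3.8-fold higher number from compound 1 to compound 2 (0.58 log units; beyond the scatter) replaces a hydrogen with fluoro and keeps the bromo. On these two steps, the expected change in this assay is a 1.4-fold higher number from compound 1 to compound 4 (0.14 log units; within the scatter), no step beyond the scatter, with a slight lean towards a higher number. The estimate for compound 4 is 18000 nM, expected between 7000 nM and 45000 nM.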

Compound 4, half-maximal inhibitory concentration: 13900 nM
Estimate against measurement, compound 4: 1.3-fold (0.11 log units) above; low and high end bracket the measured number.
By their numbers in this assay, from the lowest: compounds 1, 4 and 3 (each within the scatter of the next). At a limit, above all of these: compound 2.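

In this assay, fluoro in place of bromo on this aromatic carbon, para to a large group, leaves the number within the scatter: a 1.1-fold higher number from compound 1 to compound 4 (0.03 log units; within the scatter). Fluoro in place of nitro there does the same, a 1.3-fold lower number from compound 3 to compound 4 (0.13 log units; within the scatter), so bromo, nitro and fluoro at this position cannot be told apart. Only the step from the 4-bromo-2-fluorophenyl compound lies beyond the scatter, an at least 3.5-fold lower number from compound 2 to compound 4 (0.55 log units; beyond the scatter), and it rests on a limit held by compound 2: the limit of > 50000 nM in this assay, at which 1 of the 4 values shown sits.

On these data alone, whether an amine or a methoxy group at this position would also stay within the scatter remains open. Also open, as far as these compounds go, is whether the second fluoro of compound 2 would go with the same loss when fluoro replaces its bromo.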